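Replacing the nitrophenoxy group with a phenylsulfonyl group

A few compounds are considered here, and "the series" means these few. Any claim that something is new, unique, unknown or untested is made for them only; others in the source may bear on it.

Three compounds share one core and differ in the group attached through an oxygen on a saturated carbon. Compound 1 `CC(C)(C)c1ccc(OC(C)(C)C2OCC(C/C=C\CCC(=O)O)C(c3cccnc3)O2)cc1` gives 280 nM in an assay for inhibition of Thromboxane-A synthase (Homo sapiens), using microsomes; a lower number here means a stronger inhibitor, a higher number a weaker inhibitor. Compound 2 `COc1ccccc1OC(C)(C)C1OCC(C/C=C\CCC(=O)O)C(c2cccnc2)O1` gives 60 nM in this assay, which is a 4.7-fold lower number from compound 1 to compound 2 (0.67 log units; beyond the scatter). Compound 3 `CC(C)(Oc1ccccc1[N+](=O)[O-])C1OCC(C/C=C\CCC(=O)O)C(c2cccnc2)O1` reaches < 10 nM in this assay, and this is a limit of the assay rather than a number. Compound 3 therefore stands at the limit of < 10 nM in this assay, at which 1 of the 3 values shown sits, the lowest point among the three, with an at least 28-fold lower number from compound 1 to compound 3 (1.44 log units; beyond the scatter) and an at least 6.0-fold lower number from compound 2 to compound 3 (0.77 log units; beyond the scatter).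

Compound 4 `CC(C)(C1OCC(C/C=C\CCC(=O)O)C(c2cccnc2)O1)S(=O)(=O)c1ccccc1` is not yet measured. It differs from compound 3 by phenylsulfonyl in place of 2-nitrophenoxy on a saturated chain carbon bound to two saturated chain carbons and a saturated ring carbon. The measured steps all swap one aromatic substituent for another while keeping the oxygen link in place; none of them removes that link or exchanges the nitro group for a sulfonyl, so they give only an indirect guide. Since the move from compound 1 through compound 2 to compound 3 shows that this side group can shift the number strongly, and compound 4 loses the nitro group that accompanied the strongest result, a modest move toward a higher number in this assay is expected, amounting to an at least 8.0-fold higher number from compound 3 to compound 4 (0.90 log units; beyond the scatter). Compound 4 is thus estimated at 80 nM, with a plausible range from 10 nM to 600 nM.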

Compound 4, half-maximal inhibitory concentration: 40 nM
Compound 4: the middle estimate sits 2.0-fold (0.30 log units) above what was measured; low and high end bracket the measured number.
By their numbers in this assay, from the lowest: compounds 4 and 2 (each within the scatter of the next); then compound 1. At a limit, below all of these: compound 3.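

In this assay, for the compounds shown here, this position on a saturated chain carbon does not depend on an oxygen link to the aromatic ring, as the earlier compounds, which all kept that oxygen, could not show. With phenylsulfonyl in this place, the change gives a 7.0-fold lower number from compound 1 to compound 4 (0.85 log units; beyond the scatter), and it gives a 1.5-fold lower number from compound 2 to compound 4 (0.18 log units; within the scatter), so compound 4 cannot be told apart from compound 2 even though the link and the ring substituent have both changed. The 2-nitrophenoxy group still stands apart, with an at least 4.0-fold higher number from compound 3 to compound 4 (0.60 log units; beyond the scatter), but compound 3 sits at a limit of the assay rather than at a number, and the full size of that step stays unknown: the limit of < 10 nM in this assay, at which 1 of the 4 values shown sits.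

Compound 4 differs from compound 3 in both the link and the nitro group, so the contribution of each cannot be separated from these compounds. A plain phenoxy group would isolate the effect of the nitro group on the oxygen-linked ring, while a 2-nitrophenylsulfonyl group would show whether a nitro group on the ring gives a lower number when the link is a sulfonyl.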